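The source may report more compounds than this note shows. Statements on the series, on what has been measured and on what is new or still open speak of the compounds shown alone.

In a functional assay on the whole organism with Mus musculus as the target, at a dose of 100 mg/kg by the intraperitoneal route (on this read-out lower numbers stand for less inhibition and higher numbers for more inhibition at the one dose given (going by the name of the read-out)), three compounds have been measured. Compound 1 `CN(C)C(=O)/C=C1\CCc2ccc(F)cc21` gives 100%. Compound 2 `CCN(C)C(=O)/C=C1\CCc2c(F)cc(F)cc21`, which carries ethyl(methyl)amino on a carbonyl carbon, gives 100%. Compound 3 `CC(C)NC(=O)/C=C1\CCc2ccc(F)cc21` gives 100%. Compound 3 therefore stands level with compound 1 and compound 2 at the digits shown, and the one single-point step measured, no change at the digits printed from compound 1 to compound 3 (within the scatter), shows no change beyond the scatter.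

Compound 4 `CCN(C)C(=O)/C=C1\CCc2ccc(F)cc21` differs from compound 3 in one place: ethyl(methyl)amino in place of isopropylamino on a carbonyl carbon. Two pieces of evidence bear on this. First, the ethyl(methyl)amino group entering here already sits on a carbonyl carbon in compound 2, whose read-out matches compound 3. Second, exchanging the group on the carbonyl carbon in no change at the digits printed from compound 1 to compound 3 (within the scatter) left the read-out untouched. Nothing in these data points to a shift beyond the scatter, so the expected step is no change at the digits printed from compound 3 to compound 4 (within the scatter), none beyond the scatter.

Compound 4 is accordingly estimated to give 100%, with a range from 85% to 100%.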

Compound 4, a percentage reported as inhibition, in the whole organism at one dose (the size of the read-out at that dose, not a potency): 100%
For compound 4 middle estimate and measured number coincide at the digits printed; measured number inside the range.
By their numbers in this assay, from the lowest: compounds 1, 2, 3 and 4 (each within the scatter of the next).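

In this assay, the swap on the carbonyl carbon gives no change at the digits printed from compound 3 to compound 4 (within the scatter), so replacing isopropylamino, with 1 hydrogen-bond donor, by ethyl(methyl)amino, with 0 hydrogen-bond donors, leaves the read-out level at this position. The two other single-place comparisons point the same way: hydrogen in place of fluoro on an aromatic carbon gives no change at the digits printed from compound 2 to compound 4 (within the scatter), and methyl in place of hydrogen on a saturated chain carbon bound to an amide-type nitrogen gives no change at the digits printed from compound 1 to compound 4 (within the scatter). No measurement shown here accounts for these results.

All four compounds read the same at a single dose, so any difference in potency between them stays hidden. On these data alone, it also remains open whether a carboxylic acid or a longer chain such as hexylamino on the carbonyl carbon would keep this read-out.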